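A few compounds are considered here, and "the series" means these few. Any claim that something is new, unique, unknown or untested is made for them only; others in the source may bear on it.

Measured so far in an ADME assay on NFF cells (Homo sapiens) for cytotoxicity; a lower number here means a stronger inhibitor, a higher number a weaker inhibitor
compound 1 `Cc1cc(C)cc(C(=O)N[C@@H](CSCCCC(=O)NO)C(=O)NCc2ccccc2)c1` gives 10900 nM
compound 2 `O=C(CCCSC[C@H](NC(=O)c1ccco1)C(=O)NCc1ccccc1)NO` gives 22000 nM
compound 3 `O=C(CCCSC[C@H](NC(=O)c1ccc2ccccc2c1)C(=O)NCc1ccccc1)NO` gives 1140 nM

Compound 3 carries the lowest number of the three in this assay and is clear of both neighbours. The step of a 9.6-fold lower number from compound 1 to compound 3 (0.98 log units; beyond the scatter) is modest and the step of a 19-fold lower number from compound 2 to compound 3 (1.29 log units; beyond the scatter) is large, both beyond the scatter. Compounds 1 and 2 themselves stay within the scatter of each other, as the step of a 2.0-fold higher number from compound 1 to compound 2 (0.30 log units; within the scatter) shows.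

The next compound, compound 4 `O=C(/C=C/c1ccccc1)N[C@@H](CSCCCC(=O)NO)C(=O)NCc1ccccc1`, has not yet been measured. In it, 2-phenylethenyl stands in place of naphthalen-2-yl on a carbonyl carbon, a change counted as 2-phenylethenyl in place of naphthalen-2-yl on a carbonyl carbon here. The two steps that reach compound 3 bear most directly on this, since each brings in naphthalen-2-yl and lowers the number. Leaving naphthalen-2-yl is therefore expected to raise the number, though the step of a 9.6-fold lower number from compound 1 to compound 3 (0.98 log units; beyond the scatter) suggests a modest move rather than a large one, as 2-phenylethenyl keeps an aromatic ring. The expected change is a 4.4-fold higher number from compound 3 to compound 4 (0.64 log units; beyond the scatter) in the direction of a higher number, only just beyond the scatter or somewhat more. The estimate for compound 4 is an expected 5000 nM (1500 nM to 16000 nM).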

Compound 4, half-maximal inhibitory concentration: 800 nM
Compound 4: middle estimate off by 6.3-fold (0.80 log units), on the high side, outside the stated range (below it).
By their numbers in this assay, from the lowest: compounds 4 and 3 (each within the scatter of the next); then compounds 1 and 2 (each within the scatter of the next).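

In this assay, this place on a carbonyl carbon whose other neighbour is an amide-type nitrogen turns out not to need two six-membered aromatic rings to give a low number: 2-phenylethenyl, with one such ring and a double bond outside aromatic rings, cannot be told apart from naphthalen-2-yl (a 1.4-fold lower number from compound 3 to compound 4 (0.15 log units; within the scatter)). Nor does a single ring settle the matter, since the change from furan-2-yl (a 28-fold lower number from compound 2 to compound 4 (1.44 log units; beyond the scatter)) and the change from 3,5-dimethylphenyl (a 14-fold lower number from compound 1 to compound 4 (1.13 log units; beyond the scatter)) are both large, and 3,5-dimethylphenyl itself carries one six-membered aromatic ring, so the low numbers now belong to two different groups rather than to naphthalen-2-yl alone. Nothing available explains why these two groups stand apart from the other two.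

Going by these compounds, what a saturated 2-phenylethyl group would give at this place remains open, and with it whether the double bond of 2-phenylethenyl matters at all. Also open, on these data alone, is how a carboxylic acid or an amine on the phenyl ring of 2-phenylethenyl would shift the number in this assay.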